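A few compounds are considered here, and "the series" means these few. Any claim that something is new, unique, unknown or untested is made for them only; others in the source may bear on it.

Compound 1 `COc1ccc2c(c1)c(O)c(C(=O)O)c(=O)n2C`: > 10000 nM
Compound 2 `Cn1c(=O)c(C(=O)O)c(O)c2cc(Cc3ccccc3)ccc21`: > 10000 nM
Compound 3 `Cn1c(=O)c(C(=O)O)c(O)c2cc(Cc3ccc(F)cc3)ccc21`: > 10000 nM

All three compounds were tested in a functional assay on HCT-116 cells (Homo sapiens) for cytotoxicity, read by MTT assay, with a stated time of 72 h (a lower number here means that less compound is tolerated, a higher number that more compound is tolerated), and none gave a number. Compound 3 stands at > 10000 nM, which is a limit of the assay and not a measured value. The two other compounds share that position: the limit of > 10000 nM in this assay, at which 3 of the 3 values shown sit.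

Compound 4 `Cn1c(=O)c(C(=O)O)c(O)c2cc(Oc3ccccc3)ccc21` carries phenoxy in place of 4-fluorobenzyl on an aromatic carbon of the shared core: phenoxy in place of 4-fluorobenzyl on an aromatic carbon.

Going by the values given here, three measured steps bear on this change, and none has a readable size. Fluoro in place of hydrogen gave a step that the two limits leave unreadable from compound 2 to compound 3. Benzyl in place of methoxy gave a step that the two limits leave unreadable from compound 1 to compound 2. 4-Fluorobenzyl in place of methoxy gave a step that the two limits leave unreadable from compound 1 to compound 3.

These steps therefore give no sign of a direction, and no shift beyond the scatter is expected in this assay. The expected outcome is a step that the limit leaves unreadable from compound 3 to compound 4. Compound 4 will most likely also reach the limit of the assay. Compound 4 is estimated at 12000 nM, with an expected range from 5000 nM to 30000 nM.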

Compound 4, half-maximal cytotoxic concentration: > 10000 nM
Compound 4: a limit, no number (the forecaster's own chance of this, stated with the estimate: 85%); the middle value does not contradict the limit.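

The steps to compound 4 from compound 1, compound 2 and compound 3 cannot be read, as all four compounds give a limit and no number: the limit of > 10000 nM in this assay, at which 4 of the 4 values shown sit. The compounds shown leave open whether any change on the shared core shifts cytotoxicity in these cells at all.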